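Chloro for methyl on a triazole-linked sulfonamide series

The source may hold more compounds than are shown below. What is called first, only, known or untested is meant among the compounds shown, and "the series" means these compounds.

Compound 1, `Cc1ccc(-n2cc(-c3ccccc3NS(=O)(=O)c3c[nH]c(=O)[nH]c3=O)nn2)cc1`, gives > 100000 nM in an ADME assay on L02 cells (Homo sapiens) for cytotoxicity, read by MTT assay, with a stated time of 24 h (on this read-out higher numbers stand for lower toxicity in this test and lower numbers for higher toxicity in this test), which is a limit of the assay and not a number.
Compound 2, `O=c1[nH]cc(S(=O)(=O)Nc2ccccc2-c2cn(-c3ccc(F)cc3)nn2)c(=O)[nH]1`, is recorded as "not toxic" (no number reported) in this assay, with no number.
Compound 3, `Cc1ccccc1-n1cc(-c2cccc(NS(=O)(=O)c3c[nH]c(=O)[nH]c3=O)c2)nn1`, gives 15300 nM in this assay.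

For the measured compounds named here, compound 3 therefore stands as the only compound of the three with a measured number; one other entry is a limit, at which (the limit of > 100000 nM in this assay, at which 1 of the 3 values shown sits), and the remaining entry carries no number at all. Nothing in these three values can be set against one another as a measured step, so no change between measured compounds is available to guide the next move.

Compound 4, `O=c1[nH]cc(S(=O)(=O)Nc2cccc(-c3cn(-c4ccccc4Cl)nn3)c2)c(=O)[nH]1`, differs from compound 3 by chloro in place of methyl on an aromatic carbon, which, taken one bond further out, reads 2-methylphenyl to 2-chlorophenyl. With no measured step of this kind among the compounds shown, the expectation for compound 4 is a change from compound 3 of no more than the ordinary scatter, in no particular direction. Compound 4 is thus estimated at 20000 nM in this assay, with a range from 6000 nM to 80000 nM. That expectation corresponds to a step of a 1.3-fold higher number from compound 3 to compound 4 (0.12 log units; within the scatter).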

Compound 4, half-maximal cytotoxic concentration: 11500 nM
The estimate for compound 4 lay 1.7-fold (0.24 log units) above the measured number; measured number inside the range.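

Chloro in place of methyl, on an aromatic carbon ortho to a large group, gives a 1.3-fold lower number from compound 3 to compound 4 (0.12 log units; within the scatter) in this assay, and this is the first step among the compounds shown that can be read between two measured numbers. It shows that, at this position, the change from 2-methylphenyl to 2-chlorophenyl does not separate compound 3 from compound 4 on this read-out, so the series now has a second measured number, and the two lie within the scatter of each other. Nothing shown bears on why these two groups read alike, and no measured property accompanies the step.

This single step leaves open whether a group of another kind at the same place, such as an amine or a carboxylic acid, would move the number in this assay beyond the scatter. For the compounds shown here, compound 1 remains at > 100000 nM, which is a limit of the assay and not a number, so it offers no measured step, and the entry for compound 2 carries no number either.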